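This account rests on a few compounds, and the source may have more. Where it says the series, first, only, none or still open, it means among the compounds named here.

Measured so far in a functional assay on KG-1 cells (Homo sapiens) for cytotoxicity, read by luminescence and CellTiter-Glo, with a stated time of 3 days; on this read-out higher numbers stand for weaker inhibition and lower numbers for stronger inhibition:
- compound 1, `O=C(Nc1ccc(OC(F)(F)F)cc1)c1cc(F)ccc1O`: 780 nM
- compound 2, `Cc1ccc(C(=O)Nc2ccc(C#N)cc2)c(O)c1`: 2560 nM
- compound 3, `N#Cc1ccc(NC(=O)c2cc(-c3ccncc3)ccc2O)cc1`: 7990 nM

Compound 2 gives the second highest of the three numbers in this assay: compound 3 sits above it beyond the scatter, compound 1 below it beyond the scatter.

Compound 4, `N#Cc1ccc(NC(=O)c2ccc(Br)cc2O)cc1`, is not yet measured. It differs from compound 2 in one place: bromo in place of methyl on an aromatic carbon. For the measured compounds named here, no measured pair isolates this change, so its effect is open; a step no larger than the scatter, or a slight move downward, is the expectation for the step of a 1.3-fold lower number from compound 2 to compound 4 (0.11 log units; within the scatter). Compound 4 is therefore estimated at 2000 nM in this assay, with a range from 700 nM to 6000 nM.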

Compound 4, half-maximal inhibitory concentration: 1450 nM
For compound 4 the middle estimate is 1.4-fold (0.14 log units) above the measured one; the measured number falls inside the stated range.
By their numbers in this assay, from the lowest: compounds 1, 4 and 2 (each within the scatter of the next, the first and the last beyond it); then compound 3.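

In this assay, bromo in place of methyl on this aromatic carbon, meta to a hydroxy group and para to a large group, gives a 1.8-fold lower number from compound 2 to compound 4 (0.25 log units; within the scatter) and so separates the two groups by no more than the scatter. For the compounds shown here, this is the first one-place comparison, and it rests on a single pair. No available evidence bears on why the two groups read alike.

Going by these compounds, an amine or a carboxylic acid on this carbon remains open. Also open, on these data alone, is whether bromo in place of methyl gives a similar step on the core of compound 1.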